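This account rests on a few compounds, and the source may have more. Where it says the series, first, only, none or still open, it means among the compounds named here.

The series rests on one shared core, carried by compound 1 `COc1ccc2c(C(=O)c3cc(OC)c(OC)c(OC)c3N)c[nH]c2c1`, by compound 2 `COc1cc(Cc2c[nH]c3ccccc23)c(N)c(OC)c1OC`, by compound 3 `COc1cc(Cc2c[nH]c3c(OC)cccc23)c(N)c(OC)c1OC` and by the still unmeasured compound 4 `COc1cc(Cc2c[nH]c3cc(F)ccc23)c(N)c(OC)c1OC`. In a functional assay on HT-29 cells (Homo sapiens) for cytotoxicity, read by sulforhodamine B assay, with a stated time of 48 h (on this read-out higher numbers stand for weaker inhibition of growth and lower numbers for stronger inhibition of growth), compound 1 gives 143 nM. Compound 2 reaches only a limit of this assay, reported as > 100000 nM, so no single number stands for it. Compound 3 is reported in this assay as "not active" (no number reported), again with no number attached. Among the measured compounds shown here, compound 2 therefore stands at the weak end of what has been measured, sitting at the limit of > 100000 nM in this assay, at which 1 of the 3 values shown sits, with compound 3 beside it in lacking a figure and compound 1 the only member with a measured value. For the measured compounds named here, no step between two measured compounds is available, so no size of change can be read from the data directly. The change from compound 2 to compound 4 is fluoro in place of hydrogen on an aromatic carbon. With compound 2 resting at the limit of > 100000 nM in this assay, at which 1 of the 3 values shown sits, the step expected from this change is a number no higher from compound 2 to compound 4 (the limit leaves the size open), that is, none beyond the usual scatter. Compound 4 is accordingly estimated in this assay at 100000 nM, within a range from 20000 nM to 300000 nM, and most probably reported again only as a limit.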

Compound 4, concentration for 50% growth inhibition: "not active" (no number reported)
Compound 4 has no reported number here; there is nothing to compare the estimate with.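

Among the compounds shown here, compound 4 is reported as not active with no number attached, and compound 2 stands only at a limit, so no step from compound 2 to compound 4 can be read. The compounds shown leave open how far, if at all, fluoro in place of hydrogen on this aromatic carbon shifts the result in this assay.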